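Halogen swap on the fused ring: expected step

This account rests on a few compounds, and the source may have more. Where it says the series, first, only, none or still open, it means among the compounds named here.

Compound 1 `O=C(O)CN1C(=O)/C(=C/c2nc3ccccc3n2Cc2ccc(F)cc2)SC1=S` and compound 2 `O=C(O)CN1C(=O)/C(=C/c2nc3ccccc3n2Cc2ccc(Cl)cc2)SC1=S` share one core and differ in a single place. In a functional assay on A549 cells (Homo sapiens) for cytotoxicity, read by MTT assay, with a stated time of 48 h (a higher number here means a weaker inhibitor, a lower number a stronger inhibitor), compound 1 gives 3570 nM and compound 2 gives 17500 nM; the change fluoro in place of chloro on an aromatic carbon produces a 4.9-fold lower number from compound 2 to compound 1 (0.69 log units; beyond the scatter). Compound 3 `O=C(O)CN1C(=O)/C(=C/c2nc3cc(Cl)ccc3n2Cc2ccccc2F)SC1=S` carries a core whose difference from that of compound 2 is not broken down here; in this assay compound 3 gives 5640 nM. Compound 4 `O=C(O)CN1C(=O)/C(=C/c2nc3cc(F)ccc3n2Cc2ccccc2F)SC1=S` is not yet measured and arises from compound 3 by fluoro in place of chloro on an aromatic carbon, the same kind of change as that from compound 2 to compound 1, but now on a ring that is part of a fused or bridged system of two rings, meta to a fused ring and para to a fused ring, rather than para to a large group. Because the earlier swap gave a 4.9-fold lower number from compound 2 to compound 1 (0.69 log units; beyond the scatter), the step in this assay is expected in the same direction but smaller, a 1.6-fold lower number from compound 3 to compound 4 (0.21 log units; within the scatter), since the place is not the same. Compound 4 is expected to give 3500 nM, within 1500 nM to 9000 nM.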

Compound 4, half-maximal inhibitory concentration: 32700 nM
Beside the measured number, compound 4's estimate is 9.3-fold (0.97 log units) below it; the whole stated range lies below it.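

In this assay, fluoro in place of chloro on an aromatic carbon of the fused system gives a 5.8-fold higher number from compound 3 to compound 4 (0.76 log units; beyond the scatter), the opposite direction to the earlier swap, which gave a 4.9-fold lower number from compound 2 to compound 1 (0.69 log units; beyond the scatter). The change therefore does not carry from one core to the other as a fixed increment, and even its direction is not preserved across these two pairs: the same change on two cores in this assay, a 4.9-fold lower number (0.69 log units; beyond the scatter) from compound 2 to compound 1 and a 5.8-fold higher number (0.76 log units; beyond the scatter) from compound 3 to compound 4, 28-fold (1.45 log units) apart, beyond the scatter of two such steps. The two pairs differ both in the place of the swap and in the rest of the core, so they do not show which of these sets the direction, nor why it reverses.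

Still open, as far as these compounds go, is how other groups at this place on the fused ring, such as a methoxy group or an amine, would read out in this assay. Also open, from the compounds shown here alone, is whether the same reversal appears when the halogen swap is made on further cores.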